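The source may report more compounds than this note shows. Statements on the series, on what has been measured and on what is new or still open speak of the compounds shown alone.

Measured compounds:
compound 1 `O=C(N/N=C/c1c[nH]nc1-c1cccc(Cl)c1)c1ccncc1` — in an ADME assay on Vero cells (Chlorocebus sabaeus) for inhibition, read by MTT assay, with a stated time of 3 days (on this read-out higher numbers stand for weaker inhibition and lower numbers for stronger inhibition), compound 1 gives > 1000 ug/mL, a limit of the assay.
compound 2 `O=C(c1ccncc1)N(/N=C/c1c[nH]nc1-c1ccc(Cl)cc1)C(=O)c1ccc(CCl)cc1` — in this assay compound 2 gives > 1000 ug/mL, likewise a limit.

Within the data shown here, compound 1 thus stands only at a limit, and so does the one other value shown (the limit of > 1000 ug/mL in this assay, at which 2 of the 2 values shown sit). Compound 3 `O=C(c1ccncc1)N(/N=C/c1c[nH]nc1-c1cccc(Cl)c1)C(=O)c1ccc(F)cc1` differs from compound 1 by (4-fluorophenyl)carbonyl in place of hydrogen on an amide-type nitrogen. Among the measured compounds shown here, no step between measured compounds exists, so the expectation rests on these limits alone: the step from compound 1 to compound 3 is estimated as a number no higher from compound 1 to compound 3 (the limit leaves the size open), none beyond the scatter. Compound 3 is accordingly expected to give about 1000 ug/mL, between 500 ug/mL and 2000 ug/mL, most likely reported again as a limit.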

Compound 3, half-maximal inhibitory concentration: > 1000 ug/mL
Compound 3: only a limit was reported (the forecaster's own chance of this, stated with the estimate: 85%); the middle value lies on the limit itself.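

Among these compounds, compound 1 and compound 3 both stand only at a limit, so no step between them can be read: the limit of > 1000 ug/mL in this assay, at which 3 of the 3 values shown sit.
The compounds shown leave open whether (4-fluorophenyl)carbonyl in place of hydrogen changes the true inhibition in this assay.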